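The compounds below may be only part of what the source reports. "The series", "measured", "known", "first", "only" and "open" are said of these compounds alone.

Measured so far in a functional assay on MOLT-4 cells (Homo sapiens) for antiproliferative activity; on this read-out lower numbers stand for stronger inhibition and higher numbers for weaker inhibition:
compound 1 `COc1cc(C(=O)c2sc(-c3ccc([N+](=O)[O-])cc3)cc2N)cc(OC)c1OC`: 110 nM
compound 2 `COc1cc(C(=O)c2sc(-c3ccc(F)cc3)cc2N)cc(OC)c1OC`: 12 nM
compound 3 `COc1cc(C(=O)c2sc(-c3ccc(C)cc3)cc2N)cc(OC)c1OC`: 16 nM

Compound 3 sits level with compound 2 at the low end of these three numbers, with the step between them given as a 1.3-fold higher number from compound 2 to compound 3 (0.12 log units; within the scatter). The gap to the nitro compound is clear: a 6.9-fold lower number from compound 1 to compound 3 (0.84 log units; beyond the scatter).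

The next structure is compound 4 `COc1ccc(-c2cc(N)c(C(=O)c3cc(OC)c(OC)c(OC)c3)s2)cc1`. The change is methoxy in place of methyl on an aromatic carbon, para to a large group.

Within the data shown here, three measured steps concern this same place. Replacing nitro gave modest steps, a 9.2-fold lower number from compound 1 to compound 2 (0.96 log units; beyond the scatter) and a 6.9-fold lower number from compound 1 to compound 3 (0.84 log units; beyond the scatter), while fluoro to methyl gave only a 1.3-fold higher number from compound 2 to compound 3 (0.12 log units; within the scatter). Among the measured compounds shown here, only the steps from compound 1 go beyond the scatter, and no methoxy compound has been measured yet. In this assay, no step beyond the scatter is therefore expected, though a modest rise cannot be excluded.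

The expected step is a 1.1-fold lower number from compound 3 to compound 4 (0.03 log units; within the scatter).

The estimate for compound 4 is 15 nM, with an expected range of 5 nM to 50 nM.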

Compound 4, half-maximal inhibitory concentration: 18 nM
Estimate against measurement, compound 4: 1.2-fold (0.08 log units) below; measured number inside the range.
By their numbers in this assay, from the lowest: compounds 2, 3 and 4 (each within the scatter of the next); then compound 1.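

In this assay the change from 4-methylphenyl to 4-methoxyphenyl brings in an oxygen at this position without a readable shift (a 1.1-fold higher number from compound 3 to compound 4 (0.05 log units; within the scatter)), and methoxy in place of fluoro also stays within the scatter (a 1.5-fold higher number from compound 2 to compound 4 (0.18 log units; within the scatter)). Methoxy in place of nitro remains a step beyond the scatter (a 6.1-fold lower number from compound 1 to compound 4 (0.79 log units; beyond the scatter)), so among these four compounds fluoro, methyl and methoxy cannot be told apart, while only the nitro compound stands apart from them. No measurement shown here offers an explanation for this grouping.

On these data alone, it remains open whether an amine or a carboxylic acid at this place would fall with the nitro compound or with the other three. A longer chain, such as butoxy, is equally undecided.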